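Silicon for carbon on the triazole of compound 1

The compounds below may be only part of what the source reports. "The series", "measured", "known", "first", "only" and "open" are said of these compounds alone.

Within the data shown here, compound 1 `CC(C)(C)c1cn(C[C@H](O)[C@H]2OC(=O)C(OCc3ccccc3)=C2OCc2ccccc2)nn1` is the weakest point of the three measured members: in a functional assay on HeLa cells (Homo sapiens) for antiproliferative activity, read by MTT assay, with a stated time of 72 h (a lower number here means a stronger inhibitor, a higher number a weaker inhibitor), compound 1 gives 18300 nM, the highest of the three numbers. Compound 2 `O=C1O/C(=C\Cn2cc(-c3cc(F)cc(F)c3)nn2)C(OCc2ccccc2)=C1OCc1ccccc1` gives 17700 nM, which sits within the scatter of compound 1. Compound 3 `Cc1ccc(-c2cn(C/C=C3\OC(=O)C(OCc4ccccc4)=C3OCc3ccccc3)nn2)cc1` gives 7480 nM, and the gap from compound 1 to compound 3 is beyond the scatter.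

Compound 4 `C[Si](C)(C)c1cn(C[C@H](O)[C@H]2OC(=O)C(OCc3ccccc3)=C2OCc2ccccc2)nn1` differs from compound 1 in one place: a group of 4 heavy atoms (3 carbon, 1 silicon; no ring) in place of a group of 4 heavy atoms (4 carbon; no ring), on an aromatic carbon. The group that enters has no common name; it carries one silicon in place of one carbon, on an aromatic carbon of the five-membered aromatic ring with 3 nitrogen.

Among the measured compounds shown here, the only measured step, a 2.4-fold lower number from compound 2 to compound 3 (0.37 log units; beyond the scatter), swaps one aryl group for another on that same ring and is only modest in size; it does not touch a tert-butyl, so nothing measured bears directly on the change from compound 1 to compound 4. With no comparable step shown, the expectation is a step of a 1.1-fold lower number from compound 1 to compound 4 (0.06 log units; within the scatter), that is, none beyond the scatter. Compound 4 is therefore estimated at 16000 nM in this assay, within a range of 7000 nM to 36000 nM.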

Compound 4, half-maximal inhibitory concentration: 22300 nM
Compound 4: the middle estimate sits 1.4-fold (0.14 log units) below what was measured, and the stated range covers the measured number.
By their numbers in this assay, from the lowest: compound 3; then compounds 2, 1 and 4 (each within the scatter of the next).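

In this assay, the one-atom exchange of silicon for carbon on the aromatic carbon of the five-membered aromatic ring with 3 nitrogen gives a 1.2-fold higher number from compound 1 to compound 4 (0.09 log units; within the scatter), so this assay does not separate the tert-butyl group from its silicon-containing counterpart. Among these compounds, this is the first step read on the core of compound 1 and the first between two groups without a ring at this position, whereas the earlier step, a 2.4-fold lower number from compound 2 to compound 3 (0.37 log units; beyond the scatter), exchanged one aryl group for another on a different core. No measured evidence bears on why the exchange leaves the number within the scatter.

As far as these compounds go, the two groups compared here have the same count of heavy atoms and neither has a ring, so it remains open whether a more different group at this ring carbon on the core of compound 1 would move the number beyond the scatter. A primary amine, a carboxylic acid, an n-hexyl chain or the 4-methylphenyl group of compound 3 at this position would each put that question to the test.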